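The source may report more compounds than this note shows. Statements on the series, on what has been measured and on what is new or still open speak of the compounds shown alone.

Three compounds share one core and were tested in a functional assay on HepG2 cells (Homo sapiens) for antiproliferative activity, read by spectrophotometry, with a stated time of 2 days; on this read-out lower numbers stand for stronger inhibition of growth and higher numbers for weaker inhibition of growth. Compound 1, `COc1cc(N2CCN(C(C)=O)CC2)ccc1Nc1ncc(C(F)(F)F)c(N2Cc3cccc(N(C)S(C)(=O)=O)c3C2)n1`, gives 3800 nM. Compound 2, `CN(c1cccc2c1CN(c1nc(Nc3cccc(Oc4ccccc4)c3)ncc1C(F)(F)F)C2)S(C)(=O)=O`, gives 23000 nM. Compound 3, `CN(c1cccc2c1CN(c1nc(Nc3cc(C(F)(F)F)cc(C(F)(F)F)c3)ncc1C(F)(F)F)C2)S(C)(=O)=O`, gives 10300 nM. Among these three numbers, compound 3 stands second highest: its nearest neighbour is compound 2, with a higher number, and its furthest is compound 1, with a lower number, and both of those gaps lie beyond the usual scatter of this assay.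

Compound 4, `CN(c1cccc2c1CN(c1nc(Nc3cc(Cl)cc(C(F)(F)F)c3)ncc1C(F)(F)F)C2)S(C)(=O)=O`, has not yet been measured. It differs from compound 3 in one place: chloro in place of trifluoromethyl on an aromatic carbon. The group that leaves has four heavy atoms and the one that enters has a single heavy atom, but neither carries any hydrogen-bond donor or acceptor or net charge. Going by the values given here, with only one such swap, and no measured step of this kind among the three compounds to compare against, the expected change from compound 3 to compound 4 is small, so a 1.3-fold lower number from compound 3 to compound 4 (0.11 log units; within the scatter) is estimated to stay within the scatter, leaning toward a slightly lower number. For compound 4 the expected result in this assay is 8000 nM, with a range from 3500 nM to 18000 nM.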

Compound 4, concentration for 50% growth inhibition: 9900 nM
For compound 4 the middle estimate is 1.2-fold (0.09 log units) below the measured one; the range from low to high includes it.
By their numbers in this assay, from the lowest: compound 1; then compounds 4 and 3 (each within the scatter of the next); then compound 2.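

In this assay, going by these compounds alone, putting chloro in place of trifluoromethyl on this aromatic carbon, meta to a trifluoromethyl group, gives a 1.0-fold lower number from compound 3 to compound 4 (0.02 log units; within the scatter) and provides the first measured step here that changes only one place. At this position, a group of four heavy atoms and a group of one heavy atom, both with no hydrogen-bond donors or acceptors and no net charge, cannot be told apart by this read-out. The heavy-atom count can therefore drop here with no change beyond the scatter, at least for this one pair of groups.

Going by these compounds, whether an amine or a carboxylic acid on the same aromatic carbon would also leave the number within the scatter remains open. Nothing available here bears on why chloro and trifluoromethyl read alike at this position.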